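Adding an Ethyl Group to an Amide Nitrogen

This account rests on a few compounds, and the source may have more. Where it says the series, first, only, none or still open, it means among the compounds named here.

Compound 1, `Cc1ccc(CNC(=O)c2nn(-c3ccc(F)cc3)c(CC[C@@H](O)C[C@@H](O)CC(=O)O)c2C(C)C)cc1`: in an assay on microsomes from liver for inhibition of 3-hydroxy-3-methylglutaryl-coenzyme A reductase (Rattus norvegicus) (a higher number here means a weaker inhibitor, a lower number a stronger inhibitor), compound 1 gives 2.5 nM.
Compound 2, `CC(C)c1c(C(=O)N(C)Cc2cccc(F)c2)nn(-c2ccc(F)cc2)c1CC[C@@H](O)C[C@@H](O)CC(=O)O`: in this assay compound 2 gives 4.1 nM.
Compound 3, `CC(C)c1c(C(=O)NCc2ccccc2)nn(-c2ccc(F)cc2)c1OC[C@@H](O)C[C@@H](O)CC(=O)O`: in this assay compound 3 gives 3.8 nM.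

Compound 3 holds the second highest of the three numbers, yet all three lie within the scatter of one another, so none of the three can be called stronger or weaker than the others on these data. Compound 4, `CCN(Cc1ccccc1)C(=O)c1nn(-c2ccc(F)cc2)c(OC[C@@H](O)C[C@@H](O)CC(=O)O)c1C(C)C`, has not yet been measured. It differs from compound 3 by ethyl in place of hydrogen on an amide-type nitrogen. Among the compounds with values here, only one measured step touches the amide nitrogen: a 1.6-fold higher number from compound 1 to compound 2 (0.21 log units; within the scatter). There a methyl group entered that nitrogen while the benzyl part also changed, and the number hardly moved. In the change from compound 3 to compound 4 only the substituent on the nitrogen changes, and it is a small one. On that basis no step beyond the scatter is expected in this assay; the expected step is a 1.2-fold higher number from compound 3 to compound 4 (0.07 log units; within the scatter). Compound 4 is therefore estimated at 4.5 nM, with a range from 2 nM to 11 nM, the width of the range reflecting that a single related step is all there is to go on.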

Compound 4, half-maximal inhibitory concentration: 14 nM
The estimate for compound 4 lay 3.1-fold (0.49 log units) below the measured number, outside the stated range (above it).
By their numbers in this assay, from the lowest: compounds 1, 3 and 2 (each within the scatter of the next); then compound 4.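

In this assay, within the data shown here, replacing the amide hydrogen with ethyl gives a 3.7-fold higher number from compound 3 to compound 4 (0.57 log units; beyond the scatter) and is the first step at this nitrogen that lies beyond the scatter, though its size is modest. The earlier step, a 1.6-fold higher number from compound 1 to compound 2 (0.21 log units; within the scatter), put a methyl on the same nitrogen while the benzyl part changed too, so it could not show what the nitrogen substituent does alone; here nothing else changes, and the result shows that this position does not freely accept a small added group when the rest of compound 3 is held fixed. Nothing in the available data explains why adding the ethyl raises the number.

The compounds shown leave open whether a methyl alone on this nitrogen of compound 3 would stay within the scatter of compound 3 or give a step like the one to compound 4, and whether a longer chain such as propyl would raise the number further. They also leave open whether an ethyl on the amide nitrogen of compound 1 would give a step of similar size on that different core.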